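The source may hold more compounds than are shown below. What is called first, only, known or untested is meant among the compounds shown, and "the series" means these compounds.

Compounds measured so far:
Compound 1 `O=C(Nc1cc(-c2ccccc2)nn1-c1ccccc1)c1ccccn1`: 585 nM
Compound 2 `O=C(Nc1cc(-c2ccccc2)nn1-c1ccccc1)c1ccc(C(F)(F)F)cc1`: 20 nM

Both values come from an assay on isolated protein with metabotropic glutamate receptor 5 (Rattus norvegicus) as the target; on this read-out lower numbers stand for an effect already at smaller amounts and higher numbers for an effect only at larger amounts of compound. Compound 2 stands at the lower of the two numbers: the nearest measured compound is compound 1, and the step of a 29-fold lower number from compound 1 to compound 2 (1.47 log units; beyond the scatter) separates them, a large move lying well beyond the scatter.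

Compound 3 `Cc1cccc(C(=O)Nc2cc(-c3ccccc3)nn2-c2ccccc2)c1` has not yet been measured in this assay. It differs from compound 2 in one place: 3-methylphenyl in place of 4-(trifluoromethyl)phenyl on a carbonyl carbon. Within the data shown here, the only measured step bearing on this position is a 29-fold lower number from compound 1 to compound 2 (1.47 log units; beyond the scatter), which shows that the group on the carbonyl carbon can shift the number greatly. Among the measured compounds shown here, that step, however, exchanged pyridin-2-yl for 4-(trifluoromethyl)phenyl; no measured pair compares 3-methylphenyl with 4-(trifluoromethyl)phenyl, so its direction cannot be read from the data. The expectation is therefore cautious: compound 3 keeps a six-membered aromatic ring of carbon only on the carbonyl carbon, so the number is expected to stay closer to compound 2 than to compound 1, with the step of a 2.5-fold higher number from compound 2 to compound 3 (0.40 log units; beyond the scatter) estimated as a modest rise. Compound 3 is expected to give about 50 nM in this assay, within a range of 15 nM to 200 nM.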

Compound 3, half-maximal effective concentration: 100 nM
The estimate for compound 3 lay 2.0-fold (0.30 log units) below the measured number, within the range that was stated.
By their numbers in this assay, from the lowest: compound 2; then compound 3; then compound 1.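

In this assay, a 5.0-fold higher number from compound 2 to compound 3 (0.70 log units; beyond the scatter) shows that the group on the carbonyl carbon matters even when the ring stays a six-membered aromatic ring of carbon only: exchanging 4-(trifluoromethyl)phenyl for 3-methylphenyl moves the number beyond the scatter, so the large effect earlier seen on this carbon is not explained simply by having such a ring there. At the same time, a 5.9-fold lower number from compound 1 to compound 3 (0.77 log units; beyond the scatter) shows that 3-methylphenyl retains part, but not all, of the difference seen in a 29-fold lower number from compound 1 to compound 2 (1.47 log units; beyond the scatter), placing this group between pyridin-2-yl and 4-(trifluoromethyl)phenyl among these three compounds. No available evidence says what lies behind this ordering.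

The new change alters both the substituent and its place on the ring, so the compounds shown cannot separate the contribution of methyl versus trifluoromethyl from that of the ring position; 4-methylphenyl and 3-(trifluoromethyl)phenyl would each change only one of the two. Where an unsubstituted phenyl, a chlorine or a methoxy group would fall on this scale also remains open.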